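Removal of the 4-methoxybenzyl group across two ureas

A few compounds are considered here, and "the series" means these few. Any claim that something is new, unique, unknown or untested is made for them only; others in the source may bear on it.

Compound 1 `COc1ccc(Cn2ncc3c2NC(=O)CC(c2ccc(NC(=O)Nc4ccc(Cl)c(C(F)(F)F)c4)cc2)=N3)cc1` gives 7290 nM in a functional assay on U-937 cells (Homo sapiens) for inhibition, read by MTT assay, with a stated time of 24 h; on this read-out lower numbers stand for stronger inhibition of growth and higher numbers for weaker inhibition of growth. Compound 2 `O=C1CC(c2ccc(NC(=O)Nc3ccc(Cl)c(C(F)(F)F)c3)cc2)=Nc2cn[nH]c2N1` differs from it by hydrogen in place of 4-methoxybenzyl on an aromatic nitrogen. Compound 2 returns only a limit of the assay, > 30000 nM, in this assay. The step of an at least 4.1-fold higher number from compound 1 to compound 2 (0.61 log units; beyond the scatter) therefore rests on that limit (the limit of > 30000 nM in this assay, at which 1 of the 3 values shown sits). Compound 3 `COc1ccc(Cn2ncc3c2NC(=O)CC(c2cccc(NC(=O)Nc4ccc(Cl)cc4)c2)=N3)cc1` gives 580 nM in this assay, the lowest of the two numbers; the difference between the core of compound 3 and the core of compound 1 is not broken down here. Compound 4 `O=C1CC(c2cccc(NC(=O)Nc3ccc(Cl)cc3)c2)=Nc2cn[nH]c2N1` is not yet measured and differs from compound 3 by hydrogen in place of 4-methoxybenzyl on an aromatic nitrogen, the same change as from compound 1 to compound 2, occurring twice among the compounds shown. For compound 4 in this assay a step of about the earlier size is expected, a 14-fold higher number from compound 3 to compound 4 (1.14 log units; beyond the scatter), resting on the step of an at least 4.1-fold higher number from compound 1 to compound 2 (0.61 log units; beyond the scatter). That earlier step is bounded only by the limit (the limit of > 30000 nM in this assay, at which 1 of the 3 values shown sits); the true loss may be larger, and compound 4 may itself reach the limit. Compound 4 is estimated at 8000 nM, between 2500 nM and 30000 nM.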

Compound 4, concentration for 50% growth inhibition: > 30000 nM
Compound 4 gave a limit, no number; the forecaster's own chance of this, stated with the estimate: 30%; middle value at least 3.7-fold (0.57 log units) from the limit.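

On both cores shown, hydrogen in place of 4-methoxybenzyl on the aromatic nitrogen gives a higher number in this assay, and on the second core the result is an at least 51-fold higher number from compound 3 to compound 4 (1.71 log units; beyond the scatter). Compound 4 gives > 30000 nM, a limit of the assay and not a number, and it shares this limit with one other compound: the limit of > 30000 nM in this assay, at which 2 of the 4 values shown sit. The direction of the change therefore carries across these two cores, but the data do not show whether its size carries with it, and two cores do not establish a rule for the series: the same change on two cores in this assay, an at least 4.1-fold higher number (0.61 log units; beyond the scatter) from compound 1 to compound 2 and an at least 51-fold higher number (1.71 log units; beyond the scatter) from compound 3 to compound 4; the limit leaves it open whether they differ.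

On these data alone, it remains open whether a plain benzyl, a methyl or a longer alkyl chain on that nitrogen would give a measurable number in this assay, or whether the methoxy group of 4-methoxybenzyl matters at all. Compound 1 and compound 3 differ in more than one place, so the separate contributions of their urea substituents and of the position of the urea remain unresolved.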